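The source may hold more compounds than are shown below. What is called first, only, known or untested is meant among the compounds shown, and "the series" means these compounds.

All numbers come from an assay on membranes from striatum (strain Sprague-Dawley) for displacement of a labelled ligand from sodium-dependent dopamine transporter (Rattus norvegicus), read by scintillation counting, with a stated time of 120 min; a higher number here means a weaker inhibitor, a lower number a stronger inhibitor. Measured so far:

compound 1 `Fc1ccc(C(SCCNC2CCN(Cc3ccc(Cl)cc3)CC2)c2ccc(F)cc2)cc1`: 39.6 nM
compound 2 `Fc1ccc(C(SCCNC2CCN(Cc3cc4ccccc4[nH]3)CC2)c2ccc(F)cc2)cc1`: 179 nM
compound 3 `Fc1ccc(C(SCCNC2CCN(Cc3cc4ccccc4o3)CC2)c2ccc(F)cc2)cc1`: 120 nM

Compound 3 holds the second highest of the three numbers. Its nearest neighbour is compound 2, with a 1.5-fold lower number from compound 2 to compound 3 (0.17 log units; within the scatter), a gap within the scatter; its furthest is compound 1, with a 3.0-fold higher number from compound 1 to compound 3 (0.48 log units; beyond the scatter), beyond the scatter.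

Compound 4 `CC(C)(C)C(=O)N1CCC(NCCSC(c2ccc(F)cc2)c2ccc(F)cc2)CC1` differs from compound 3 in one place: (tert-butyl)carbonyl in place of (1-benzofuran-2-yl)methyl on an amine nitrogen in a ring. The measured steps all exchange one aromatic group for another on the chain carbon bound to the ring nitrogen: a 4.5-fold higher number from compound 1 to compound 2 (0.66 log units; beyond the scatter), a 3.0-fold higher number from compound 1 to compound 3 (0.48 log units; beyond the scatter) and a 1.5-fold lower number from compound 2 to compound 3 (0.17 log units; within the scatter). They were modest or within the scatter. None of them removes the chain carbon or places a carbonyl directly on the ring nitrogen, so they bear on the present step only loosely; every such change so far has moved the number upward from compound 1, and only compound 1 stands at the low end.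

For compound 4 a higher number than compound 3 is expected, with the step estimated as a 2.9-fold higher number from compound 3 to compound 4 (0.46 log units; beyond the scatter). The value of compound 4 in this assay is estimated at 350 nM, within a range of 80 nM to 1500 nM.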

Compound 4, inhibition constant: 352 nM
Compound 4: middle estimate off by 1.0-fold (0.00 log units), on the low side; measured number inside the range.
By their numbers in this assay, from the lowest: compound 1; then compounds 3, 2 and 4 (each within the scatter of the next, the first and the last beyond it).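

Going by these compounds alone, putting (tert-butyl)carbonyl, a group with no ring, in place of the aromatic-bearing substituents on the amine nitrogen in a ring gives the first change of group type at this position in this assay: a 2.9-fold higher number from compound 3 to compound 4 (0.47 log units; beyond the scatter), a 2.0-fold higher number from compound 2 to compound 4 (0.29 log units; within the scatter) and an 8.9-fold higher number from compound 1 to compound 4 (0.95 log units; beyond the scatter). Binding is therefore not lost without an aromatic ring at this position, since compound 4 remains within the scatter of compound 2, while the 4-chlorobenzyl group of compound 1 keeps the lowest number of the four. No supporting data bear on why the number moves with this change.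

The compounds shown leave open whether the carbonyl or the loss of the aromatic ring accounts for the step from the 4-chlorobenzyl group. A 4-chlorobenzoyl group and a 2,2-dimethylpropyl group on the same nitrogen would separate these two changes.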